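Trading Allyl for Ethyl on a Shared Core

This account rests on a few compounds, and the source may have more. Where it says the series, first, only, none or still open, it means among the compounds named here.

Measured so far in a functional assay on the whole organism with Mus musculus as the target, at a dose of 120 mg/kg; on this read-out lower numbers stand for an effect already at smaller amounts and higher numbers for an effect only at larger amounts of compound:
- Compound 1 `CCc1c(SC)nc2nc(C(=O)c3ccccc3)cn2c1C`: 12.5 mg/kg
- Compound 2 `C=CCc1c(OC)nc2nc(C(=O)c3ccccc3)cn2c1C`: 54 mg/kg

Of these two numbers, the higher belongs to compound 2 at 54 mg/kg, so it shows its effect only at the larger dose. The gap to compound 1 at 12.5 mg/kg lies beyond the usual scatter.

Compound 3 `CCc1c(OC)nc2nc(C(=O)c3ccccc3)cn2c1C` has not been measured yet. It differs from compound 2 by a single change methyl in place of vinyl on a saturated chain carbon bound to an aromatic carbon, which reads as allyl to ethyl when cut one bond further out.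

Going by the values given here, no two measured compounds differ in only one place, so the data offer no direct guide to the size of such a step. In this assay, among the compounds with values here, no step beyond the scatter is expected, with a slight lean towards a lower number, as the only other measurement, compound 1 at 12.5 mg/kg, sits lower. The estimated change is a 1.4-fold lower number from compound 2 to compound 3 (0.13 log units; within the scatter). The estimate for compound 3 is 40 mg/kg, with an expected range of 16 mg/kg to 95 mg/kg.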

Compound 3, dose for half-maximal effect: 21 mg/kg
The estimate for compound 3 lay 1.9-fold (0.28 log units) above the measured number; measured number inside the range.
By their numbers in this assay, from the lowest: compounds 1 and 3 (each within the scatter of the next); then compound 2.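

In this assay, going by these compounds alone, replacing allyl with ethyl on the saturated chain carbon bound to an aromatic carbon gives a 2.6-fold lower number from compound 2 to compound 3 (0.41 log units; beyond the scatter), which is the first direct sign that the group at this place affects the dose needed for an effect. A change elsewhere reads differently: methoxy in place of methylsulfanyl on an aromatic carbon gives a 1.7-fold higher number from compound 1 to compound 3 (0.23 log units; within the scatter), a step within the scatter, so with ethyl in the chain this pair shows no real difference between the two groups. Nothing available here explains the size of either step.

The allyl to ethyl step removes a double bond and shortens the chain at the same time, so these compounds cannot show which of the two matters, whereas a propyl group, which keeps the length of allyl without its double bond, would separate them. As far as these compounds go, it also remains open whether the trend continues beyond ethyl, towards a plain methyl group or in the other direction towards a longer butyl chain.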